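The compounds below may be only part of what the source reports. "The series", "measured", "known", "first", "only" and "open" are said of these compounds alone.

Compound 2 `COc1ccc(-c2cc(/C=C/C(=O)c3ccc(N)cc3)[nH]n2)cc1OC` and compound 1 `COc1ccc(-c2cc(/C=C/C(=O)c3ccc(N)cc3)[nH]n2)cc1` share a core and differ in one place: hydrogen in place of methoxy on an aromatic carbon. In a functional assay on NCI/ADR-RES cells (Homo sapiens) for cytotoxicity, read by sulforhodamine B assay, with a stated time of 48 h, tested at 100 uM (on this read-out lower numbers stand for a stronger effect and higher numbers for a weaker effect at the one concentration tested), compound 2 gives 2%, while compound 1 gives -38%, a step of a number 40 percentage points lower from compound 2 to compound 1 (beyond the scatter). Compound 3 `COc1cc(C(=O)/C=C/c2cc(-c3cc(OC)c(OC)c(OC)c3)n[nH]2)cc(OC)c1OC` is built on a different core, and the difference between the two cores is not broken down here. In this assay compound 3 gives -24%. Compound 4 `COc1ccc(-c2cc(/C=C/C(=O)c3cc(OC)c(OC)c(OC)c3)[nH]n2)cc1OC` is derived from compound 3 by the same kind of change: hydrogen in place of methoxy on an aromatic carbon, a place that is also meta to a methoxy group. Because a number 40 percentage points lower from compound 2 to compound 1 (beyond the scatter) was large, a step in the same direction is expected here, though the different surroundings leave it uncertain, so the expected step is a number 21 percentage points lower from compound 3 to compound 4 (beyond the scatter). Compound 4 is therefore estimated at -45%, expected to lie between -70% and -15%.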

Compound 4, a percentage reported as activity, at one concentration (the size of the read-out at that concentration, not a potency): -7%
Compound 4: the middle estimate sits 38 percentage points below what was measured; the whole stated range lies below it.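

Replacing methoxy with hydrogen gives a number 17 percentage points higher from compound 3 to compound 4 (beyond the scatter) in this assay, the opposite direction from the earlier step, and the two steps clearly differ: the same change on two cores in this assay, a number 40 percentage points lower (beyond the scatter) from compound 2 to compound 1 and a number 17 percentage points higher (beyond the scatter) from compound 3 to compound 4, 57 percentage points apart, beyond the scatter of two such steps. On these two pairs, then, the change does not carry over from one core to the other, and its direction on one core gave no safe guide to its direction on the other. These two pairs do not show which feature of the cores separates the results, or how the change would behave on any further core.

The compounds shown leave open whether a hydroxyl group or a chlorine atom in place of the methoxy would follow either step. They also leave open whether a longer chain, such as ethoxy, would do so.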